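Urotensin-2 receptor series: ester versus amide, aryl swap

The compounds below may be only part of what the source reports. "The series", "measured", "known", "first", "only" and "open" are said of these compounds alone.

Compound 1 `Cc1ccccc1C(=O)OC(CCN(C)C)c1ccc(Cl)cc1` and compound 2 `COc1ccc(C(=O)OC(CCN(C)C)c2ccc(Cl)cc2)cc1` share an ester core; compound 3 `Cc1ccccc1C(=O)NC(CCN(C)C)c1ccc(Cl)cc1` and compound 4 `COc1ccc(C(=O)NC(CCN(C)C)c2ccc(Cl)cc2)cc1` carry the amide-type nitrogen in its place. In an assay on NIH3T3 cells with Urotensin-2 receptor (Homo sapiens) as the target (on this read-out higher numbers stand for larger maximal responses and lower numbers for smaller maximal responses), compound 1 gives 126%, compound 2 gives 84% and compound 3 gives 175%. The step of a number 42 percentage points lower from compound 1 to compound 2 (beyond the scatter) is the result of 4-methoxyphenyl in place of 2-methylphenyl on a carbonyl carbon. The difference between the two cores is not broken down here. Among the measured compounds shown here, compound 4 is obtained from compound 3 by 4-methoxyphenyl in place of 2-methylphenyl on a carbonyl carbon; this is the same kind of change as the one from compound 1 to compound 2, but the carbonyl carbon is attached to an amide-type nitrogen in compound 3 and compound 4, and to an oxygen next to a carbonyl group in compound 1 and compound 2. Compound 4 has not yet been measured in this assay. For compound 4 a step of a number 45 percentage points lower from compound 3 to compound 4 (beyond the scatter) is expected, resting on compound 1 and compound 2, whose step a number 42 percentage points lower from compound 1 to compound 2 (beyond the scatter) is the only measured outcome of this change. Compound 4 is accordingly estimated at 130%, with a range from 95% to 165%.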

Compound 4, largest response reached (reported as efficacy), in percent of the reference or control that the assay uses: 162%
The estimate for compound 4 lay 32 percentage points below the measured number; low and high end bracket the measured number.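

In this assay, 4-methoxyphenyl in place of 2-methylphenyl on a carbonyl carbon gives a number 13 percentage points lower from compound 3 to compound 4 (beyond the scatter). The direction is the same on both cores, but the size does not carry over from one core to the other: the same change on two cores in this assay, a number 42 percentage points lower (beyond the scatter) from compound 1 to compound 2 and a number 13 percentage points lower (beyond the scatter) from compound 3 to compound 4, 29 percentage points apart, beyond the scatter of two such steps With one pair on each core, this supports carrying over only the direction within these four compounds, not the size of the step, and it does not show what sets the gap or whether the same direction would hold for other aryl groups.

On these data alone, it remains open whether the lower number follows the methoxy group or its place on the ring, a question that 2-methoxyphenyl and 4-methylphenyl on the carbonyl carbon would separate. Also open, as far as these compounds go, is whether the gap between the two steps persists with a longer chain leading to the amine, or with a primary amine in place of the dimethylated one.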